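The compounds below may be only part of what the source reports. "The series", "measured", "known", "first", "only" and "open" are said of these compounds alone.

Measured so far in a physicochemical assay for lipophilicity, read by HPLC, at pH 7.5; a higher number here means a more lipophilic compound, a lower number a more polar compound:
Compound 1 `CCOc1ccccc1-c1ccc(-c2nc3cnccc3c(NC(C)C(=O)O)c2C#N)cc1` gives 2.1
Compound 2 `N#Cc1c(-c2ccc(Br)cc2)nc2cnccc2c1NCC(N)=O` gives 1.9
Compound 3 `CC[C@@H](Nc1c(C#N)c(-c2ccc(-c3ncccc3C)cc2)nc2cnccc12)C(N)=O` gives 2

In this assay compound 3 gives 2 and lies within the usual scatter of both compound 1 and compound 2, so these three cannot be told apart on this number. Compound 4 `CC[C@@H](Nc1c(C#N)c(-c2ccc(-c3ccncc3C)cc2)nc2cnccc12)C(N)=O` has the same atoms as compound 3, joined differently: 3-methylpyridin-4-yl in place of 3-methylpyridin-2-yl on an aromatic carbon on an aromatic carbon of a six-membered aromatic ring of carbon only, para to a large group. Within the data shown here, no measured pair shows a step of this kind, so the expectation rests on the structural change alone. A small downward step in this assay is expected, estimated as a number 0.20 log units lower from compound 3 to compound 4 (within the scatter) and perhaps no larger than the scatter. For compound 4 the estimated value is 1.8 within an expected range from 1.4 to 2.2 for the measurement still to come.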

Compound 4, distribution coefficient: 2
The estimate for compound 4 lay 0.20 log units below the measured number; the measured number falls inside the stated range.
By their numbers in this assay, from the lowest: compounds 2, 3, 4 and 1 (each within the scatter of the next).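

Exchanging 3-methylpyridin-2-yl for 3-methylpyridin-4-yl on an aromatic carbon, para to a large group, gives no change at the digits printed from compound 3 to compound 4 (within the scatter) in this assay. Among these compounds, this is the first step at this position, and on this number the two groups cannot be told apart there. Nothing available explains this result. As far as these compounds go, whether a larger change at the same place, such as a primary amine, a morpholine or a longer alkyl chain in place of the methylpyridine, would move the number beyond the scatter remains open.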